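This account rests on a few compounds, and the source may have more. Where it says the series, first, only, none or still open, it means among the compounds named here.

Working notes on the series. Compound 2 `O=C(CSc1nnc(-c2ccncc2)o1)N/N=C/c1ccccc1O` holds the lowest of the two numbers measured in a functional assay on BGC-823 cells (Homo sapiens) for cytotoxicity, read by MTT assay, with a stated time of 48 h (on this read-out lower numbers stand for stronger inhibition and higher numbers for weaker inhibition), where compound 2 gives 6160 nM. Within the data shown here, its nearest neighbour is compound 1 `O=C(CSc1nnc(-c2ccncc2)o1)N/N=C/c1ccccc1F`, which in this assay gives 24000 nM; the only measured step is a 3.9-fold lower number from compound 1 to compound 2 (0.59 log units; beyond the scatter). Compound 3 `O=C(CSc1nnc(-c2ccncc2)o1)N/N=C/c1cc(Cl)ccc1O` is next to be measured. Its change from compound 2 is chloro in place of hydrogen on an aromatic carbon, meta to a large group and para to the hydroxy group; cut one bond further out it reads 2-hydroxyphenyl to 5-chloro-2-hydroxyphenyl. Among the measured compounds shown here, no measured step bears on a chloro at this place; the single step known concerns a different group on the same ring and gives no direction for this one. The expectation is therefore a step of about a 1.5-fold lower number from compound 2 to compound 3 (0.19 log units; within the scatter) in this assay, not clearly beyond the scatter. Compound 3 is estimated at 4000 nM, with a range from 1200 nM to 15000 nM.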

Compound 3, half-maximal inhibitory concentration: 5470 nM
Compound 3: middle estimate off by 1.4-fold (0.14 log units), on the low side; the measured number falls inside the stated range.
By their numbers in this assay, from the lowest: compounds 3 and 2 (each within the scatter of the next); then compound 1.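

In this assay, among these compounds, the step of a 1.1-fold lower number from compound 2 to compound 3 (0.05 log units; within the scatter) is the first reading at this aromatic carbon, para to a hydroxy group: a chlorine atom is tolerated here, and compound 2 and compound 3 cannot be told apart. The separation from the fluoro compound remains, with a 4.4-fold lower number from compound 1 to compound 3 (0.64 log units; beyond the scatter), but that step replaces 2-fluorophenyl with 5-chloro-2-hydroxyphenyl as a whole and gives no separate reading of the chloro. No evidence on hand bears on this result.

As far as these compounds go, whether an amine, a methoxy group or a phenyl group at this carbon would also leave the number in the range of compound 2 remains open. Also open, from the compounds shown here alone, is whether chloro at this place would behave the same way on a ring carrying fluoro rather than hydroxy.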